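The compounds below may be only part of what the source reports. "The series", "measured", "known", "first", "only" and "open" are said of these compounds alone.

In a functional assay on the whole organism (strain Wistar albino) for inhibition, with Rattus norvegicus as the target, read by paw edema, with stated times of 30 min and 3 h, at a dose of 20 mg/kg by the oral route (a higher number here means more inhibition at the dose given (going by the name of the read-out), a lower number less inhibition), compound 1 `CN(C)Cc1ccc2oc(-c3ccccc3Cl)cc(=O)c2c1` gives 54.3%. Compound 2 `NS(=O)(=O)c1ccc(NCc2ccc3oc(-c4ccccc4Cl)cc(=O)c3c2)cc1` gives 58.2% in this assay, and the two values lie within the usual scatter of each other, so neither compound stands apart. Compound 3 `COc1ccc(-c2cc(=O)c3cc(CNc4ccc(S(N)(=O)=O)cc4)ccc3o2)cc1` differs from compound 2 in one place: 4-methoxyphenyl in place of 2-chlorophenyl on an aromatic carbon. Going by the values given here, no measured pair shows this change, so its effect is unknown. Compound 2 with 58.2% is the only anchor. Compound 3 is therefore expected close to it, with an expected step of a number 3.2 percentage points lower from compound 2 to compound 3 (within the scatter), nothing beyond the scatter in either direction. For compound 3 the estimate is 55%, with a range of 40% to 68%.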

Compound 3, a percentage reported as inhibition, in the whole organism at one dose (the size of the read-out at that dose, not a potency): 60.5%
The estimate for compound 3 lay 5.5 percentage points below the measured number, within the range that was stated.
By their numbers in this assay, from the lowest: compounds 1, 2 and 3 (each within the scatter of the next).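

The step at this aromatic carbon next to the ring oxygen is a number 2.3 percentage points higher from compound 2 to compound 3 (within the scatter) in this assay when 4-methoxyphenyl takes the place of 2-chlorophenyl. At this one dose, the position therefore accepts either substituted phenyl, so the loss of chlorine and the gain of a methoxy oxygen leave the two compounds within the scatter of each other. No measured property bears on this result.

Unsubstituted phenyl and 4-chlorophenyl would separate the identity of the substituent from its place on the ring. From the compounds shown here alone, a carboxylic acid on that phenyl or a saturated cyclohexyl ring in its place remains open.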